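The source may report more compounds than this note shows. Statements on the series, on what has been measured and on what is new or still open speak of the compounds shown alone.

In a functional assay on the whole organism (strain Wistar) for inhibition, with Rattus norvegicus as the target, read by paw edema, with stated times of 60 min and 3 h, at a dose of 100 mg/kg by the oral route (a lower number here means less inhibition, a higher number more inhibition at the dose given (going by the name of the read-out)), compound 2 `COc1cc2c(cc1OC)C(CC(=O)NC(C)(C)C)CC2` gives 33.3%. For the measured compounds named here, the only other measured compound, compound 1 `COc1cc2c(cc1OC)C(CC(=O)O)CC2`, gives 27.5% in this assay, and the step of a number 5.8 percentage points higher from compound 1 to compound 2 (within the scatter) lies within the scatter, so compound 2 and compound 1 stand at the same level as far as these two numbers can tell. Compound 3 `CCCCCCNC(=O)CC1CCc2cc(OC)c(OC)cc21` differs from compound 2 in one place: hexyl in place of tert-butyl on an amide-type nitrogen. Going by the values given here, no measured step bears directly on this change; the single step measured, which put a (tert-butyl)amino in place of a hydroxy on the carbonyl carbon, was small, and it is the only guide to how much this series moves at all. The expectation for compound 3 is therefore a step of a number 0.3 percentage points lower from compound 2 to compound 3 (within the scatter) in this assay, no larger than the scatter. Compound 3 is thus estimated at 33% in this assay, with a range from 15% to 50%.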

Compound 3, a percentage reported as inhibition, in the whole organism at one dose (the size of the read-out at that dose, not a potency): 44.6%
Compound 3: the middle estimate sits 11.6 percentage points below what was measured; low and high end bracket the measured number.
By their numbers in this assay, from the lowest: compounds 1 and 2 (each within the scatter of the next); then compound 3.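

In this assay, for the compounds shown here, the group carried on the amide-type nitrogen turns out to matter: hexyl in place of tert-butyl gives a number 11.3 percentage points higher from compound 2 to compound 3 (beyond the scatter), the first step in this small set to clear the usual spread of repeat measurements. Hexylamino in place of hydroxy on the carbonyl carbon gives a number 17.1 percentage points higher from compound 1 to compound 3 (beyond the scatter), whereas (tert-butyl)amino in the same place gave only a number 5.8 percentage points higher from compound 1 to compound 2 (within the scatter), so the outcome of this replacement depends on the group attached to the nitrogen. Nothing available here explains why hexyl and tert-butyl differ.

With one branched group and one straight chain on this nitrogen, the effects of chain length and branching cannot be told apart. A butyl or octyl chain would help to separate them, while a cyclohexyl ring or a chain ending in an amine would test other kinds of group at this place.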